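The compounds below may be only part of what the source reports. "The series", "measured", "known", "first", "only" and "open" are said of these compounds alone.

Measured in an ADME assay on J774.A1 cells (Mus musculus) for cytotoxicity, read by MTT assay, with a stated time of 72 h (a lower number here means that less compound is tolerated, a higher number that more compound is tolerated), so far:
Compound 1 `CC(C)c1ccc(C(Nc2ccc(C3(C)NC(=O)c4ccccc4N3)cc2)c2nnnn2C2CCCCC2)cc1` gives > 400000 nM as a limit
Compound 2 `CC(C)c1ccc(C(Nc2ccc(C3(C)NC(=O)c4ccccc4N3)cc2)c2nnnn2C(C)(C)C)cc1` gives > 400000 nM as a limit
Compound 3 `CC(C)(C)Nc1nc(Nc2ccc(C3(C)NC(=O)c4ccccc4N3)cc2)nc(NC(C)(C)C)n1` gives 60700 nM as a number

Compound 2 stands at the limit of > 400000 nM in this assay, at which 2 of the 3 values shown sit, and therefore has a limit rather than a number. Among the measured compounds shown here, the one measured step, a step that the two limits leave unreadable from compound 1 to compound 2, is tert-butyl in place of cyclohexyl on an aromatic nitrogen. It concerns a different place in the molecule and gives no size to carry over. For the measured compounds named here, compound 3 gives 60700 nM as the only true number, yet no measured step joins it to compound 2.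

Compound 4 `CC1(c2ccc(NC(c3ccc(Br)cc3)c3nnnn3C(C)(C)C)cc2)NC(=O)c2ccccc2N1` differs from compound 2 at one place (bromo in place of isopropyl on an aromatic carbon) with bromo in place of isopropyl on an aromatic carbon, para to a large group. Going by the values given here, no measured step covers this change, so no step beyond the scatter is expected in this assay and another limit reading is quite possible. The expected step is an at least 1.1-fold lower number from compound 2 to compound 4 (0.05 log units; that floor lies within the scatter) and nothing larger. The estimate for compound 4 is 350000 nM with an expected range of 100000 nM to 400000 nM in this measurement.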

Compound 4, half-maximal cytotoxic concentration: 400000 nM
Estimate against measurement, compound 4: 1.1-fold (0.06 log units) below; the measured number falls inside the stated range.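

In this assay, among the compounds shown here, compound 4 gives 400000 nM, a true number rather than a limit, and this is the first reading for a change on an aromatic carbon, para to a large group, where 4-bromophenyl replaces 4-isopropylphenyl. For the compounds shown here, the only earlier step concerned tert-butyl and cyclohexyl on an aromatic nitrogen, whereas this one reads as a number no higher from compound 2 to compound 4 (the limit leaves the size open). Its size stays open because compound 2 holds only a limit: the limit of > 400000 nM in this assay, at which 2 of the 4 values shown sit.

On these data alone, what a methoxy group, an amine or a carboxylic acid would give in place of bromo remains open. As far as these compounds go, it is also open whether bromo would give a similar reading with cyclohexyl in place of tert-butyl on the aromatic nitrogen, and no single change links compound 3 to compound 4.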